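Biphenyl in Place of tert-Butyl on a Two-Carbon Linker

A few compounds are considered here, and "the series" means these few. Any claim that something is new, unique, unknown or untested is made for them only; others in the source may bear on it.

Measured compounds:
Compound 1 `O=S(=O)(NCCCNCc1cccc2ccccc12)c1cc(C(F)(F)F)cc(C(F)(F)F)c1` gives 2400 nM in a functional assay on HPAC cells (Homo sapiens) for inhibition, read by MTT assay, with a stated time of 72 h; a higher number here means a weaker inhibitor of growth, a lower number a stronger inhibitor of growth.
Compound 3 `O=S(=O)(NCCCNCc1ccc(Cl)cc1)c1cc(C(F)(F)F)cc(C(F)(F)F)c1` gives 2800 nM in this assay.
Compound 2 `CC(C)(C)c1ccc(CNCCNS(=O)(=O)c2cc(C(F)(F)F)cc(C(F)(F)F)c2)cc1` gives 14000 nM in this assay.

Compound 2 stands at the highest of the three numbers, so it is the weakest inhibitor of growth among them; its nearest neighbour is compound 3, and compound 1 lies furthest away, both well beyond the scatter. Compound 4 `O=S(=O)(NCCNCc1ccc(-c2ccccc2)cc1)c1cc(C(F)(F)F)cc(C(F)(F)F)c1` keeps the core of compound 2 and changes only one place: phenyl in place of tert-butyl on an aromatic carbon.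

Among the measured compounds shown here, the single measured step, a 1.2-fold higher number from compound 1 to compound 3 (0.07 log units; within the scatter), concerns a different part of the molecule and a different chain length, and it stayed within the scatter. For the measured compounds named here, no measured step covers an aromatic group replacing tert-butyl, so there is no direct guide. Given that the one measured change among these compounds left the number essentially unchanged, the step from compound 2 is expected to be small: a 1.4-fold lower number from compound 2 to compound 4 (0.15 log units; within the scatter). Compound 4 is therefore estimated at 10000 nM, with a range from 3000 nM to 30000 nM.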

Compound 4, concentration for 50% growth inhibition: 2800 nM
Compound 4: the middle estimate sits 3.6-fold (0.55 log units) above what was measured; measured number outside the range, below it.
By their numbers in this assay, from the lowest: compounds 1, 3 and 4 (each within the scatter of the next); then compound 2.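

In this assay, phenyl in place of tert-butyl on an aromatic carbon gives a 5.0-fold lower number from compound 2 to compound 4 (0.70 log units; beyond the scatter), the only step among these compounds that lies beyond the scatter. This position, para to a large group, therefore responds to what sits on it, even though both groups contain only carbon, have no hydrogen-bond donors or acceptors and carry no net charge. No measurement available here explains the stronger growth inhibition, so its cause remains unknown.

Going by these compounds, whether a methoxy group or a carboxylic acid at this same position would match phenyl or fall back toward tert-butyl remains open. It is also unclear whether the same swap would produce a step of similar size on a compound with a longer chain, such as the chain carried by compound 1 and compound 3.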